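Isobutyl to sec-butyl: a small change awaiting measurement

A few compounds are considered here, and "the series" means these few. Any claim that something is new, unique, unknown or untested is made for them only; others in the source may bear on it.

In a functional assay on the whole organism with Scenedesmus acutus as the target (a higher number here means a weaker inhibitor, a lower number a stronger inhibitor), compound 1 (`CCOC(=O)c1cc(N2C(=O)C3=C(CCCC3)C2=O)ccc1Cl`) gives 1380 nM and compound 2 (`CC(C)COC(=O)c1cc(N2C(=O)C3=C(CCCC3)C2=O)ccc1Cl`) gives 759 nM. These two values lie within the scatter of each other, so compound 2 cannot be told apart from compound 1. Compound 3 (`CCC(C)OC(=O)c1cc(N2C(=O)C3=C(CCCC3)C2=O)ccc1Cl`) keeps the shared core and changes only the chain: sec-butyl in place of isobutyl on an oxygen next to a carbonyl group. The same atoms are simply joined differently. For the measured compounds named here, one measured step bears on this, a 1.8-fold lower number from compound 1 to compound 2 (0.26 log units; within the scatter), and it stays within the scatter. It altered the same chain in a different way, so it is thin evidence. No step beyond the scatter is therefore expected in this assay. The estimated step is a 1.2-fold higher number from compound 2 to compound 3 (0.07 log units; within the scatter). For compound 3 the expected value is 900 nM, with an estimated range of 420 nM to 1900 nM.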

Compound 3, half-maximal inhibitory concentration: 794 nM
For compound 3 the middle estimate is 1.1-fold (0.05 log units) above the measured one; measured number inside the range.
By their numbers in this assay, from the lowest: compounds 2, 3 and 1 (each within the scatter of the next).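

In this assay rearranging the same atoms from isobutyl to sec-butyl, on an oxygen next to a carbonyl group, gives a 1.0-fold higher number from compound 2 to compound 3 (0.02 log units; within the scatter) and so moving the branch within this chain produces no difference that can be told from scatter. Starting from the ethyl chain instead, the step is a 1.7-fold lower number from compound 1 to compound 3 (0.24 log units; within the scatter) and so sec-butyl, like isobutyl, cannot be told apart from ethyl here. Nothing measured alongside these numbers explains why the three chains read alike.

All three chains are small and open, so this position has been probed only over a narrow range. From the compounds shown here alone, whether a longer chain such as n-octyl, a ring such as cyclohexyl or benzyl, or a carboxylic acid in place of the chain would give a step beyond the scatter remains open.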